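A few compounds are considered here, and "the series" means these few. Any claim that something is new, unique, unknown or untested is made for them only; others in the source may bear on it.

Three compounds share one core and differ only in the aryl group carried on an amide-type nitrogen. Compound 1 `CN(C)C(=O)c1cc2cnc(Nc3ccc(NC(=O)C4(C(=O)Nc5ccccc5F)CC4)cc3)nc2n1C1CCCC1` carries a 2-fluorophenyl there, compound 2 `Cc1ccc(NC(=O)C2(C(=O)Nc3ccc(Nc4ncc5cc(C(=O)N(C)C)n(C6CCCC6)c5n4)cc3)CC2)cc1` a 4-methylphenyl, and compound 3 `CN(C)C(=O)c1cc2cnc(Nc3ccc(NC(=O)C4(C(=O)Nc5ccc(O)cc5)CC4)cc3)nc2n1C1CCCC1` a 4-hydroxyphenyl. In a functional assay on T47D cells (Homo sapiens) for inhibition, read by CCK-8 assay, with a stated time of 72 h, tested at 1 uM (a higher number here means more inhibition of growth at the concentration tested, a lower number less inhibition of growth), compound 1 gives 85.2%, compound 2 gives 47.9%, and compound 3 gives 91.5%. Compound 3 thus holds the highest of the three numbers, though its gap to compound 1 lies within the scatter; only compound 2 sits clearly apart, as the steps of a number 37.3 percentage points lower from compound 1 to compound 2 (beyond the scatter) and a number 43.6 percentage points higher from compound 2 to compound 3 (beyond the scatter) show, while a number 6.3 percentage points higher from compound 1 to compound 3 (within the scatter) stays within the scatter.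

Compound 4 `CN(C)C(=O)c1cc2cnc(Nc3ccc(NC(=O)C4(C(=O)Nc5cccc(F)c5)CC4)cc3)nc2n1C1CCCC1` is the next step from compound 3: 3-fluorophenyl in place of 4-hydroxyphenyl on an amide-type nitrogen. Compound 1, which already carries a fluorine on the same ring, is the nearest measured guide, and its step to compound 3 was small. A modest drop in this assay is therefore expected, estimated as a number 11.5 percentage points lower from compound 3 to compound 4 (beyond the scatter). Compound 4 is expected to give 80%, with a range from 55% to 95%.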

Compound 4, percent growth inhibition at one concentration: -3.2%
The estimate for compound 4 lay 83.2 percentage points above the measured number; measured number outside the range, below it.
By their numbers in this assay, from the lowest: compound 4; then compound 2; then compounds 1 and 3 (each within the scatter of the next).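

In this assay, going by these compounds alone, this position proves far more sensitive than the earlier compounds suggested, with a number 94.7 percentage points lower from compound 3 to compound 4 (beyond the scatter) and, against the weaker neighbour, a number 51.1 percentage points lower from compound 2 to compound 4 (beyond the scatter) as well. The most telling step is a number 88.4 percentage points lower from compound 1 to compound 4 (beyond the scatter). Both groups in it are fluorophenyls, so at this amide-type nitrogen a fluorine on the ring does not by itself keep the growth inhibition, and 2-fluorophenyl and 3-fluorophenyl are far from interchangeable. Nothing available here accounts for this sharp difference between the two fluorophenyl groups.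

On these data alone, what remains open is whether the loss goes with the 3-substituted ring or with fluorine there, which 3-hydroxyphenyl and 4-fluorophenyl would help to separate. It is also unknown whether 4-aminophenyl, which carries an amine, would match 4-hydroxyphenyl.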